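Triazine-substituted butenolides in a hepatoma cell growth assay

This account rests on a few compounds, and the source may have more. Where it says the series, first, only, none or still open, it means among the compounds named here.

Measured so far:
compound 1 `O=C1O/C(=C\Cn2ncc(=O)[nH]c2=O)C(OCc2ccccc2)=C1OCc1ccccc1`: 41300 nM
compound 2 `Nc1ncn(C/C=C2\OC(=O)C(OCc3ccccc3)=C2OCc2ccccc2)c(=O)n1`: 2720 nM

Compound 2 holds the lowest of the two numbers in a functional assay on HepG2 cells (Homo sapiens) for inhibition, read by MTT assay, with a stated time of 72 h; a lower number here means a stronger inhibitor, a higher number a weaker inhibitor; compound 1 stands a 15-fold lower number from compound 1 to compound 2 (1.18 log units; beyond the scatter) away from it, a step beyond the scatter. Compound 3 `O=C1O/C(=C\Cn2c(=O)[nH]c(=O)[nH]c2=O)C(OCc2ccccc2)=C1OCc1ccccc1` has not yet been measured in this assay. It differs from compound 2 in one place: a group of 9 heavy atoms (3 carbon, 3 nitrogen, 3 oxygen; one six-membered aromatic ring with 3 hetero atoms) in place of a group of 8 heavy atoms (3 carbon, 4 nitrogen, 1 oxygen; one six-membered aromatic ring with 3 hetero atoms), on a saturated chain carbon bound to a double-bonded chain carbon. Going by the values given here, the only measured step that bears on this change is the one from compound 1 to compound 2, in which the ring with the amino group replaced the ring with two carbonyl groups and the number fell by a 15-fold lower number from compound 1 to compound 2 (1.18 log units; beyond the scatter). Compound 3 reverses that direction: the entering ring carries three carbonyl groups and two hydrogen-bond donors, closer in kind to the ring of compound 1 than to that of compound 2. Compound 3 is therefore expected to give a higher number than compound 2, a step of about a 9.2-fold higher number from compound 2 to compound 3 (0.96 log units; beyond the scatter). In this assay compound 3 is estimated at 25000 nM, with a likely range from 6000 nM to 100000 nM.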

Compound 3, half-maximal inhibitory concentration: 44800 nM
For compound 3 the middle estimate is 1.8-fold (0.25 log units) below the measured one; low and high end bracket the measured number.
By their numbers in this assay, from the lowest: compound 2; then compounds 1 and 3 (each within the scatter of the next).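

With a second carbonyl-bearing ring on the saturated chain carbon bound to a double-bonded chain carbon, the earlier step from the amino-bearing ring now has a counterpart in this assay: replacing that ring with the ring of compound 3 gives a 16-fold higher number from compound 2 to compound 3 (1.22 log units; beyond the scatter), so a large difference appears from this ring change with the core unchanged. The step of a 1.1-fold higher number from compound 1 to compound 3 (0.04 log units; within the scatter) shows that the two carbonyl-bearing rings cannot be told apart in this assay, although the ring of compound 3 holds one more oxygen and one fewer hydrogen-free ring carbon position than a plain count of heavy atoms would suggest is trivial, so among the three compounds only compound 2 stands apart. Nothing shown here gives a measured reason for the size of these steps.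

Whether the amino group itself accounts for the lower number of compound 2 stays open, as does what a methylamino group, a methoxy group or a chlorine atom would give on the same ring. Also open, on these data alone, is how any of these rings would behave on a longer chain attached to the shared core.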